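A few compounds are considered here, and "the series" means these few. Any claim that something is new, unique, unknown or untested is made for them only; others in the source may bear on it.

Series notes. The shared core is that of compound 1 `CN1CCC[C@H]1COc1cncc(Cl)c1`, with a single aromatic substituent varied. In an assay on membranes from brain for displacement of a labelled ligand from Neuronal acetylcholine receptor; alpha4/beta2 (Rattus norvegicus) (on this read-out lower numbers stand for stronger inhibition and higher numbers for weaker inhibition), compound 1 gives 0.6 nM. Compound 2 `CC(=O)c1cncc(OC[C@@H]2CCCN2C)c1` carries an acetyl group in its place; in this assay compound 2 gives 1.19 nM. Among the compounds with values here, compound 2 stands with compound 1 among the two numbers so far: the only measured step, a 2.0-fold higher number from compound 1 to compound 2 (0.30 log units; within the scatter), an acetyl in place of chloro on an aromatic carbon, is within the scatter, so the two are not separated.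

The next compound, compound 3 `CN1CCC[C@H]1COc1cncc(F)c1`, differs from compound 2 in one place: fluoro in place of acetyl on an aromatic carbon. Within the data shown here, the only step that bears on it is a 2.0-fold higher number from compound 1 to compound 2 (0.30 log units; within the scatter), which shows that replacing chloro with acetyl at this aromatic carbon changed little. Fluoro, like chloro, is a single heavy atom with no hydrogen-bond acceptor, so the expectation for compound 3 is a step no larger than that, a 1.7-fold lower number from compound 2 to compound 3 (0.23 log units; within the scatter), towards the number of compound 1. The estimate for compound 3 in this assay is 0.7 nM, with a range of 0.25 nM to 2 nM.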

Compound 3, inhibition constant: 0.69 nM
Compound 3: the middle estimate sits 1.0-fold (0.01 log units) above what was measured, within the range that was stated.
By their numbers in this assay, from the lowest: compounds 1, 3 and 2 (each within the scatter of the next).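

In this assay, the step of a 1.7-fold lower number from compound 2 to compound 3 (0.24 log units; within the scatter) and the step of a 1.2-fold higher number from compound 1 to compound 3 (0.06 log units; within the scatter) both stay within the scatter, so the three groups tried at this aromatic carbon are not separated by this read-out. The new information is that the two ends of the substituent comparison give no measurable separation: acetyl, with 3 heavy atoms and 1 hydrogen-bond acceptor, and fluoro, with 1 heavy atom and no hydrogen-bond acceptor, cannot be told apart here, and neither can fluoro and chloro, so across compounds 1, 2 and 3 neither substituent size nor the presence of the acceptor is tied to a resolved difference in the number. No measurement available here gives a reason for this result.

Still open, going by these compounds, is whether any group at this position can move the number beyond the scatter, for instance an amine, a carboxylic acid, a longer chain than acetyl, or plain hydrogen on this carbon. Also open is whether the same lack of separation would hold on any read-out other than this binding measurement, since the three compounds are shown in this one alone.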